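Two butenolide triazoles measured, a tosylamide analogue awaits its number

The source may hold more compounds than are shown below. What is called first, only, known or untested is meant among the compounds shown, and "the series" means these compounds.

Compound 1 `CCCCCc1ccc(-c2cn(C[C@H](O)[C@H]3OC(=O)C(OCc4ccccc4)=C3OCc3ccccc3)nn2)cc1` gives 7460 nM in a functional assay on HepG2 cells (Homo sapiens) for antiproliferative activity, read by MTT assay, with a stated time of 72 h; on this read-out lower numbers stand for stronger inhibition and higher numbers for weaker inhibition.
Compound 2 `C[Si](C)(C)c1cn(C[C@H](O)[C@H]2OC(=O)C(OCc3ccccc3)=C2OCc2ccccc2)nn1` gives 24100 nM in this assay.

Compound 2 stands as the higher of the two numbers, with compound 1 the nearer neighbour. Compound 3 `Cc1ccc(S(=O)(=O)NCc2cn(C[C@H](O)[C@H]3OC(=O)C(OCc4ccccc4)=C3OCc3ccccc3)nn2)cc1` differs from compound 2 by a group of 12 heavy atoms (8 carbon, 1 nitrogen, 2 oxygen, 1 sulfur; one six-membered aromatic ring of carbon only) in place of a group of 4 heavy atoms (3 carbon, 1 silicon; no ring), on an aromatic carbon. Among the measured compounds shown here, the one step that bears on this change, a 3.2-fold higher number from compound 1 to compound 2 (0.51 log units; beyond the scatter), shows that exchanging the aryl-bearing group for the small silyl group raised the number modestly. Returning to a larger, ring-bearing group is therefore expected to lower the number modestly, as a 2.0-fold lower number from compound 2 to compound 3 (0.30 log units; within the scatter). Compound 3 is estimated at 12000 nM, within 4000 nM to 40000 nM.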

Compound 3, half-maximal inhibitory concentration: 24900 nM
For compound 3 the middle estimate is 2.1-fold (0.32 log units) below the measured one; the range from low to high includes it.
By their numbers in this assay, from the lowest: compound 1; then compounds 2 and 3 (each within the scatter of the next).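

In this assay the (((4-methylphenyl)sulfonyl)amino)methyl group gives a 1.0-fold higher number from compound 2 to compound 3 (0.01 log units; within the scatter) and so shows that, at this aromatic carbon, bringing back a ring-bearing group does not by itself lower the number. The 4-pentylphenyl group still stands apart, with a 3.3-fold higher number from compound 1 to compound 3 (0.52 log units; beyond the scatter) showing that the gap depends on which ring-bearing group sits there and not merely on having a ring. Nothing measured here accounts for this difference. From the compounds shown here alone, whether an amine or a carboxylic acid on this carbon would give a number nearer compound 1 or compound 3 remains open. So does the part played by the pentyl chain of compound 1, which a shorter chain would test.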